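From a limit to a number: replacing methoxycarbonyl with hydroxy

This account rests on a few compounds, and the source may have more. Where it says the series, first, only, none or still open, it means among the compounds named here.

- compound 1 `COC(=O)c1cc(C2=C(c3cc(OC)c(OC)c(OC)c3)C(=O)CC2O[SiH2]C(C)(C)C)ccc1OC` gives > 100 ug/mL as a limit
- compound 2 `COc1ccc(C2=C(c3cc(OC)c(OC)c(OC)c3)C(=O)CC2OC(C)=O)cc1NC=O` gives 8 ug/mL as a number
- compound 3 `CC(=O)OC1C/C(=N/O)C(c2ccccc2)=C1c1ccccc1` gives 9 ug/mL as a number

In an ADME assay on KB cells (Homo sapiens) for cytotoxicity, read by MTT assay, with a stated time of 72 h (on this read-out higher numbers stand for weaker inhibition and lower numbers for stronger inhibition), compound 1 gives > 100 ug/mL as its reading, which is a limit of the assay and not a number. Of the three measured compounds, it is the only one that sits at this limit. In this assay compound 2 gives 8 ug/mL and compound 3 gives 9 ug/mL as true numbers, and these two lie within the usual scatter of each other.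

The next compound is compound 4 `COc1ccc(C2=C(c3cc(OC)c(OC)c(OC)c3)C(=O)CC2O[SiH2]C(C)(C)C)cc1O` and its difference from compound 1 is hydroxy in place of methoxycarbonyl on an aromatic carbon in one place. In words, hydroxy stands in place of methoxycarbonyl on an aromatic carbon, ortho to a methoxy group, while the rest of the structure stays the same.

For the measured compounds named here, no measured pair shows this change, so any forecast is rough. Going by the values given here, the only support is that compound 2 at 8 ug/mL and compound 3 at 9 ug/mL show that real numbers occur in this small set. The expected change in this assay is an at least 25-fold lower number from compound 1 to compound 4 (1.39 log units; beyond the scatter) in the direction of stronger inhibition, and its estimated size is loose. For compound 4 the estimated value is 4 ug/mL within an expected range from 0.2 ug/mL to 60 ug/mL for now.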

Compound 4, half-maximal inhibitory concentration: 6.5 ug/mL
Compound 4: middle estimate off by 1.6-fold (0.21 log units), on the low side; measured number inside the range.
By their numbers in this assay, from the lowest: compounds 4, 2 and 3 (each within the scatter of the next). At a limit, above all of these: compound 1.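

For the compounds shown here, this is the first pair in the set that differs in one place, so it is the first direct reading of a change at this aromatic carbon, ortho to a methoxy group: with hydroxy in place of methoxycarbonyl and the rest of the structure unchanged, this assay shows an at least 15-fold lower number from compound 1 to compound 4 (1.18 log units; beyond the scatter). In this assay compound 1 gives > 100 ug/mL, which is a limit and not a number. The step therefore shows that this single change moves the reading from a limit to a true number, but gives only the smallest possible size of the change, because one end of the pair is a limit: the limit of > 100 ug/mL in this assay, at which 1 of the 4 values shown sits.

On these data alone, the pair cannot separate the loss of methoxycarbonyl from the arrival of hydroxy, as both happen in the same step and the real size of the step remains unknown. A plain hydrogen, an amine or a carboxylic acid on this same aromatic carbon would help to show which of the two matters, and whether hydroxy has any special role here.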